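Thiophen-3-yl in Place of Phenyl

A few compounds are considered here, and "the series" means these few. Any claim that something is new, unique, unknown or untested is made for them only; others in the source may bear on it.

In a functional assay on HOS cells (Homo sapiens) for inhibition, with a stated time of 72 h (a lower number here means a stronger inhibitor, a higher number a weaker inhibitor), compound 1 `NC1CCC(Nc2nc(NCc3ccc(-c4ccccc4)cc3)c3ncn(C4CCCC4)c3n2)CC1` gives 290 nM and compound 2 `NC1CCC(Nc2nc(NCc3ccc(-c4ccccc4)nc3)c3ncn(C4CCCC4)c3n2)CC1` gives 206 nM. These two numbers lie within the scatter of each other, so compound 2 stands level with compound 1. Compound 3 `NC1CCC(Nc2nc(NCc3ccc(-c4ccsc4)nc3)c3ncn(C4CCCC4)c3n2)CC1` keeps the shared core of compound 2 and changes one group: thiophen-3-yl in place of phenyl on an aromatic carbon. In short, thiophen-3-yl sits in place of phenyl on an aromatic carbon. Among the compounds with values here, only one measured step bears on this, and only indirectly: a 1.4-fold lower number from compound 1 to compound 2 (0.15 log units; within the scatter). That step altered the ring carrying the phenyl, not the phenyl itself, so no measurement tests the present swap directly. With that single step inside the scatter, no shift beyond the scatter is expected in this assay. The expected step is a 1.0-fold lower number from compound 2 to compound 3 (0.01 log units; within the scatter). Compound 3 is estimated at 200 nM, within an expected range of 90 nM to 450 nM.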

Compound 3, half-maximal inhibitory concentration: 89 nM
The estimate for compound 3 lay 2.2-fold (0.35 log units) above the measured number; the measured number lies below the stated range.
By their numbers in this assay, from the lowest: compound 3; then compounds 2 and 1 (each within the scatter of the next).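

Within the data shown here, compound 3 gives the first step that lies beyond the scatter: in this assay there is a 2.3-fold lower number from compound 2 to compound 3 (0.36 log units; beyond the scatter), so the group on the aromatic carbon next to the ring nitrogen can shift this read-out, whereas the earlier change of the ring carrying that group, a 1.4-fold lower number from compound 1 to compound 2 (0.15 log units; within the scatter), stayed within the scatter. Read as a single exchange of 6-(thiophen-3-yl)pyridin-3-yl for 4-phenylphenyl, the change gives a 3.3-fold lower number from compound 1 to compound 3 (0.51 log units; beyond the scatter), which is also modest in size. Nothing available accounts for the lower number of compound 3. As far as these compounds go, it remains open whether thiophen-2-yl, furan-3-yl or pyridin-3-yl on the same carbon would give a similar number. From the compounds shown here alone, it is equally open whether thiophen-3-yl would give a step of this size in place of the outer phenyl of compound 1.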